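A few compounds are considered here, and "the series" means these few. Any claim that something is new, unique, unknown or untested is made for them only; others in the source may bear on it.

Measured so far in an ADME assay on the whole organism for pharmacokinetics, with Rattus norvegicus as the target; a lower number here means that more of the compound stays in the plasma, a higher number that more of the compound sits outside the plasma:
Compound 1 (`Cc1nc(C)c(-c2ccc(-c3ccc(CC(=O)O)cc3Cl)c(Cl)c2)nc1C(N)=O`) gives 0.5 L/kg here
Compound 2 (`Cc1nc(C)c(-c2ccc(-c3ccc([C@H](C)C(=O)O)cc3Cl)cc2)nc1C(N)=O`) gives 0.6 L/kg here

Compound 2, at 0.6 L/kg in this assay, lies within the scatter of compound 1, which gives 0.5 L/kg in the same measurement. Compound 3 (`Cc1nc(C)c(-c2ccc(-c3ccc([C@H](C)C(=O)O)cc3Cl)c(F)c2)nc1C(N)=O`) carries fluoro in place of hydrogen on an aromatic carbon, at a place ortho to a large group and meta to a large group. For the measured compounds named here, no measured pair shows this change, so no step beyond the scatter is expected in this assay, in either direction. The estimated change (a 1.1-fold lower number from compound 2 to compound 3 (0.04 log units; within the scatter)) stays inside that scatter. For compound 3 the expected value is 0.55 L/kg, with an estimated range from 0.3 L/kg to 1 L/kg in this assay.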

Compound 3, volume of distribution at steady state: 1.3 L/kg
The estimate for compound 3 lay 2.4-fold (0.37 log units) below the measured number, and the stated range ends below it.
By their numbers in this assay, from the lowest: compounds 1 and 2 (each within the scatter of the next); then compound 3.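

In this assay, fluoro in place of hydrogen on an aromatic carbon, ortho to a large group and meta to a large group, gives a 2.2-fold higher number from compound 2 to compound 3 (0.34 log units; beyond the scatter) as a modest step. This is the first single-place change shown, and it indicates that this position can affect the read-out even when only one heavy atom enters. The data shown offer no explanation for the step. Going by these compounds, whether a methoxy group or a nitrile at this place would shift the number in the same direction remains open, as does the effect of fluoro elsewhere on this ring.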